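The source may hold more compounds than are shown below. What is called first, only, known or untested is meant among the compounds shown, and "the series" means these compounds.

Measured in a physicochemical assay, with a stated time of 30 min; a higher number here means a weaker inhibitor, a lower number a stronger inhibitor:
- compound 1 `CCc1ccc(NC(=O)C2Cc3cc(OC)c(OC)cc3C2=O)cc1` gives 76.2 ug/mL
- compound 2 `CCc1cccc(NC(=O)C2Cc3cc(OC)c(OC)cc3C2=O)c1` gives 64.1 ug/mL

Going by the values given here, compound 2 stands within the scatter of compound 1, the only other measured compound, the step being a 1.2-fold lower number from compound 1 to compound 2 (0.08 log units; within the scatter). Compound 3 `COc1cc2c(cc1OC)C(=O)C(C(=O)Nc1cccc(Cl)c1)C2` follows from compound 2 with chloro in place of ethyl on an aromatic carbon. Among the compounds with values here, that one measured step moves the ethyl group and exchanges nothing, so it bears only indirectly, and no measured step covers this exchange. In this assay no step beyond the scatter is expected, and no direction can be favoured. The expected change is a 1.0-fold lower number from compound 2 to compound 3 (0.01 log units; within the scatter). For compound 3 the estimated value is 62 ug/mL, with an expected range of 28 ug/mL to 135 ug/mL.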

Compound 3, half-maximal inhibitory concentration: 76.3 ug/mL
Compound 3: the middle estimate sits 1.2-fold (0.09 log units) below what was measured, within the range that was stated.
By their numbers in this assay, from the lowest: compounds 2, 1 and 3 (each within the scatter of the next).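

In this assay, chloro in place of ethyl gives a 1.2-fold higher number from compound 2 to compound 3 (0.08 log units; within the scatter) on this aromatic carbon, meta to a large group, and 3-chlorophenyl in place of 4-ethylphenyl gives a 1.0-fold higher number from compound 1 to compound 3 (0.00 log units; within the scatter) on the amide-type nitrogen. This position therefore accepts a single chlorine atom as well as ethyl, with neither exchange moving beyond the scatter. Nothing available accounts for this flat result.

Going by these compounds, whether an amine, a carboxylic acid or a longer chain at this position would give a step beyond the scatter remains open. Also open, on these data alone, is whether chloro behaves the same at the position held by the ethyl group of compound 1.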